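A Second Chloro Group on Two Related Cores

The compounds below may be only part of what the source reports. "The series", "measured", "known", "first", "only" and "open" are said of these compounds alone.

Measured compounds:
compound 1, `C=C[C@@](C)(/C=C/c1ccc(O)c(/C=C/c2ccc(Cl)cc2)c1)CCC=C(C)C`, > 36600 nM
compound 2, `C=C[C@@](C)(/C=C/c1ccc(O)c(/C=C/c2ccc(Cl)c(Cl)c2)c1)CCC=C(C)C`, > 7500 nM
compound 3, `C=C[C@@](C)(/C=C/c1ccc(-c2ccc(Cl)cc2)cc1)CCC=C(C)C`, > 36600 nM

Three compounds were tested in a functional assay on SEM cells (Homo sapiens) for cytotoxicity, with a stated time of 72 h; a lower number here means that less compound is needed, a higher number that more compound is needed for the effect. Compound 1 gives only a limit of the assay there, > 36600 nM. Compound 2 likewise gives only a limit, > 7500 nM. Compound 3 also stops at a limit, > 36600 nM. Compound 2 differs from compound 1 by chloro in place of hydrogen on an aromatic carbon, and the measured step reads a step that the two limits leave unreadable from compound 1 to compound 2. The difference between the core of compound 1 and the core of compound 3 is not broken down here.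

The unmeasured compound 4, `C=C[C@@](C)(/C=C/c1ccc(-c2ccc(Cl)c(Cl)c2)cc1)CCC=C(C)C`, differs from compound 3 by chloro in place of hydrogen on an aromatic carbon; this is the same change as from compound 1 to compound 2, at the same place. Since compound 1 and compound 3 both sit at the limit of > 36600 nM in this assay, at which 2 of the 3 values shown sit, and compound 2 at the limit of > 7500 nM in this assay, at which 1 of the 3 values shown sits, the series gives no readable number on which to expect activity. Compound 4 is therefore expected to reach only a limit again, a step that the limit leaves unreadable from compound 3 to compound 4. The estimated value of compound 4 is 40000 nM, expected between 8000 nM and 200000 nM.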

Compound 4, half-maximal effective concentration: > 36600 nM
Compound 4: a limit, no number (the forecaster's own chance of this, stated with the estimate: 80%); the middle value is on the limit's open side.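

In this assay compound 4 gives only a limit, > 36600 nM. Compound 3 also ends at a limit, so the step between compound 3 and compound 4 cannot be read. The compounds shown leave open whether the change from 4-chlorophenyl to 3,4-dichlorophenyl alters the concentration needed for cytotoxicity on either core.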